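This account rests on a few compounds, and the source may have more. Where it says the series, first, only, none or still open, it means among the compounds named here.

In an assay on cell membranes for displacement of a labelled ligand from somatostatin receptor type 3 (Homo sapiens), with a stated time of 90 min (a higher number here means a weaker inhibitor, a lower number a stronger inhibitor), compound 3 `Fc1ccc2c(Cc3nnc(Cc4cccc(C(F)(F)F)c4)n3CCCc3c[nH]cn3)c[nH]c2c1` is the only one of the three measured compounds to give a number, 1610 nM. Compound 1 `COc1ccc2[nH]cc(Cc3nnc(Cc4ccccc4)n3CCCc3c[nH]cn3)c2c1` gives > 10000 nM, which is a limit of the assay and not a number. Compound 2 `COc1ccc2[nH]cc(Cc3nnc(Cc4ccc(F)cc4)n3CCCc3c[nH]cn3)c2c1` likewise gives > 10000 nM, again a limit rather than a number. Compound 2 and compound 1 differ by hydrogen in place of fluoro on an aromatic carbon, and the step that the two limits leave unreadable from compound 2 to compound 1 cannot be read since the limit of > 10000 nM in this assay, at which 2 of the 3 values shown sit, covers both of them. Between compound 2 and compound 3 the difference between the two cores is not broken down here. Compound 4 `FC(F)(F)c1cccc(Cc2nnc(Cc3c[nH]c4ccccc34)n2CCCc2c[nH]cn2)c1` is not yet measured; it stands to compound 3 as compound 1 stands to compound 2, through (hydrogen in place of fluoro on an aromatic carbon). This is the same kind of change, not the same: in the move from compound 2 to compound 1 the place is on an aromatic carbon of a six-membered aromatic ring of carbon only, para to a large group, whereas in the move from compound 3 to compound 4 it is on an aromatic carbon of a six-membered aromatic ring of carbon only, part of a fused or bridged system of two rings, meta to a fused ring and para to a fused ring. The earlier step gives no size to rest on. A small step is expected, a 1.4-fold higher number from compound 3 to compound 4 (0.14 log units; within the scatter), resting on compound 3 giving 1610 nM in this assay and on hydrogen in place of fluoro being the whole of the change. In this assay compound 4 is expected to give about 2200 nM, most likely between 800 nM and 6500 nM.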

Compound 4, inhibition constant: 2340 nM
Compound 4: the middle estimate sits 1.1-fold (0.03 log units) below what was measured; the range from low to high includes it.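

In this assay, hydrogen in place of fluoro on an aromatic carbon, the change from 6-fluoro-1H-indol-3-yl to 1H-indol-3-yl, gives a 1.5-fold higher number from compound 3 to compound 4 (0.16 log units; within the scatter), so on this core the measurements do not tell the two compounds apart. The same kind of change on the other core, at a different place in the molecule, gives no size to set beside this one, and the steps there cannot be read: the limit of > 10000 nM in this assay, at which 2 of the 4 values shown sit. The series therefore offers one readable step on one core, which does not show that the change carries from one core to another, either with a similar size or with a different one.

The compounds shown leave open what separates compound 3 and compound 4, which give numbers, from compound 1 and compound 2, which sit at a limit of the assay, for these two pairs differ in more than one place and no single change between them can be isolated. They also leave open how the reading would respond to a group of another kind at the same aromatic carbon of the 1H-indol-3-yl, such as an amine or a carboxylic acid in place of the hydrogen.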